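Carbonyl substituent change on the core of compound 2

The source may report more compounds than this note shows. Statements on the series, on what has been measured and on what is new or still open speak of the compounds shown alone.

Of the compounds shown here, two carry numbers so far. Compound 1 `Cn1cc(/C=C(\C#N)S(C)(=O)=O)c2ccccc21` reaches only a limit in a functional assay on MT4 cells (Homo sapiens) for antiproliferative activity, read by MTT assay, with a stated time of 96 h; on this read-out higher numbers stand for an effect only at larger amounts of compound and lower numbers for an effect already at smaller amounts: compound 1 gives > 100000 nM, which is a limit of the assay and not a number. This is the limit of > 100000 nM in this assay, at which 1 of the 2 values shown sits. Within the data shown here, compound 2 `N#C/C(=C\c1c(-c2ccccc2)[nH]c2ccccc12)C(=O)N1CCCCC1` is the one compound with a measured number in this assay: compound 2 gives 9600 nM. Compound 2 therefore stands alone among the numbers shown, the further value being a limit.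

Compound 3 `N#C/C(=C\c1c(-c2ccccc2)[nH]c2ccccc12)C(=O)c1ccccc1` has not yet been measured in this assay. It differs from compound 2 by phenyl in place of piperidin-1-yl on a carbonyl carbon. Among the measured compounds shown here, no measured step of this kind is known, so the size of the step rests on expectation only. The change is expected to move the value by a small amount, probably not beyond the usual scatter, with a slight lean toward lower numbers. On that basis compound 3 is estimated at 7000 nM in this assay, with a range from 2000 nM to 30000 nM, which is expected to mean a step of a 1.4-fold lower number from compound 2 to compound 3 (0.14 log units; within the scatter).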

Compound 3, half-maximal effective concentration: 500 nM
The estimate for compound 3 lay 14-fold (1.15 log units) above the measured number; the whole stated range lies above it.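

In this assay, the group on this carbonyl carbon, whose other neighbour is the double-bonded chain carbon, proves to matter on the shared core: phenyl in place of piperidin-1-yl gives a 19-fold lower number from compound 2 to compound 3 (1.28 log units; beyond the scatter). Among these compounds, this is the first step that can be read, and it shows that a change at this one place can carry the value well beyond the usual scatter. The two groups match in their counts of heavy atoms, hydrogen-bond donors and acceptors and in net charge, differing in that a six-membered aromatic ring of carbon only replaces a six-membered non-aromatic ring with a hetero atom, and nothing measured here gives a cause for the step.

A single step cannot separate what phenyl brings from what the loss of piperidin-1-yl removes, and a cyclohexyl ring, a morpholin-4-yl group or a pyridyl ring on the same carbonyl carbon would bear on that question. Compound 1 differs from the others in more than one place and gives > 100000 nM, a limit of the assay and not a number, so it adds nothing to the reading of this position.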